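A Pyridine-to-Imidazole Swap on a Shared Core

The source may report more compounds than this note shows. Statements on the series, on what has been measured and on what is new or still open speak of the compounds shown alone.

Compound 1 `Cc1nc(-c2cnc(NC3CC3)[nH]c2=O)ccc1Oc1ccnc(-c2cnn(C)c2)c1`: 55 nM
Compound 2 `CCNc1ncc(-c2ccc(Oc3ccnc(-c4ccc(C)nc4)c3)c(C)n2)c(=O)[nH]1`: 1200 nM

Of the compounds shown here, two have been measured in a functional assay on NFS-60 cells (Mus musculus) for antiproliferative activity, read by resazurin assay, with a stated time of 72 h; on this read-out higher numbers stand for weaker inhibition and lower numbers for stronger inhibition. Compound 1 gives 55 nM in this assay, and compound 2 gives 1200 nM. Compound 2 thus stands at the higher of the two numbers, and its gap to compound 1 lies well beyond the scatter of repeated measurements. The two compounds differ in more than one place, so no single change can be read from that gap.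

Compound 3 `CCNc1ncc(-c2ccc(Oc3ccnc(-n4cnc(C)c4)c3)c(C)n2)c(=O)[nH]1` has not yet been measured. It differs from compound 2 in one place: 4-methyl-1H-imidazol-1-yl in place of 6-methylpyridin-3-yl on an aromatic carbon. Among the compounds with values here, only one pair of measured compounds exists, and it does not isolate this change, so the expectation rests on little. A step from compound 2 to compound 3 of a 2.4-fold lower number from compound 2 to compound 3 (0.38 log units; beyond the scatter) is expected, a modest move toward a lower number that may still sit within the scatter. Compound 3 is estimated to give 500 nM, with a likely range from 120 nM to 2000 nM.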

Compound 3, half-maximal inhibitory concentration: 2800 nM
Compound 3: the middle estimate sits 5.6-fold (0.75 log units) below what was measured; measured number outside the range, above it.
By their numbers in this assay, from the lowest: compound 1; then compound 2; then compound 3.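

Within the data shown here, this is the first pair that isolates a single change. In this assay, placing 4-methyl-1H-imidazol-1-yl instead of 6-methylpyridin-3-yl on this aromatic carbon, next to the ring nitrogen, gives a 2.3-fold higher number from compound 2 to compound 3 (0.37 log units; beyond the scatter) as a modest loss of inhibition, so the result at this position does depend on the group it carries, and here the five-membered aromatic ring does worse than the six-membered one. No measurement at hand explains this shift.

Among these compounds, only one pair carries this change, so it remains unknown whether the same swap would have a similar effect on another compound. Also open, from the compounds shown here alone, is how an amine such as morpholine, or a carboxylic acid, would compare with either ring at this position.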